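Hydroxy to amino: notes ahead of compound 3

The source may report more compounds than this note shows. Statements on the series, on what has been measured and on what is new or still open speak of the compounds shown alone.

compound 1 `[N-]=[N+]=NCC/C(=C(\c1ccccc1)c1ccc(OCCO)cc1)c1ccccc1`: > 100000 nM (a limit)
compound 2 `NCC/C(=C(\c1ccccc1)c1ccc(OCCO)cc1)c1ccccc1`: 12400 nM

In a functional assay on MCF7 cells (Homo sapiens) for cytotoxicity, read by MTT assay, with a stated time of 96 h (on this read-out lower numbers stand for stronger inhibition and higher numbers for weaker inhibition), compound 1 gives > 100000 nM, which is a limit and not a number. Among the compounds with values here, compound 2, at 12400 nM, holds the only number so far. Compound 3 `NCCOc1ccc(/C(=C(/CCN)c2ccccc2)c2ccccc2)cc1` is not yet measured. The change is amino in place of hydroxy on a saturated chain carbon, two bonds along the chain from an oxygen on an aromatic ring. Within the data shown here, only one measured step bears on it, and only loosely: compound 2 arose with an at least 8.0-fold lower number from compound 1 to compound 2 (0.90 log units; beyond the scatter), where amino replaced azido at a different place and a different group left. A modest move to a lower number is therefore expected in this assay, possibly not much beyond the scatter. For compound 3 the expected value is 6000 nM, with an estimated range of 1800 nM to 20000 nM. The expected step is a 2.1-fold lower number from compound 2 to compound 3 (0.32 log units; beyond the scatter).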

Compound 3, half-maximal inhibitory concentration: 11200 nM
For compound 3 the middle estimate is 1.9-fold (0.27 log units) below the measured one, and the stated range covers the measured number.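

In this assay, amino in place of hydroxy on a saturated chain carbon, two bonds along the chain from an oxygen on an aromatic ring, gives a 1.1-fold lower number from compound 2 to compound 3 (0.04 log units; within the scatter). Within the data shown here, this is the first reading at the 2-hydroxyethoxy end of the series, and it does not separate 2-aminoethoxy from 2-hydroxyethoxy, whereas the only earlier step, at the other chain, was an at least 8.0-fold lower number from compound 1 to compound 2 (0.90 log units; beyond the scatter). Nothing at hand bears on why this exchange leaves the number within the scatter.

The compounds shown leave open whether a dimethylamino group, a carboxylic acid or a longer chain at this place would move the number beyond the scatter. As far as these compounds go, whether 2-aminoethoxy and 2-hydroxyethoxy also stay level on cells other than MCF7 remains open too.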